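Dropping the Benzothiophene: What Propylsulfanyl Might Cost

The compounds below may be only part of what the source reports. "The series", "measured", "known", "first", "only" and "open" are said of these compounds alone.

Measured so far in a functional assay on PC-9 cells (Homo sapiens) for inhibition, read by MTT assay, with a stated time of 72 h; on this read-out lower numbers stand for stronger inhibition and higher numbers for weaker inhibition:
- compound 1, `Cc1cc(Nc2cc(-c3ccccc3)[nH]n2)n2nc(SCc3csc4ccccc34)nc2n1`, gives 4420 nM
- compound 2, `Cc1cc(Nc2cc(-c3ccc(Cl)cc3)[nH]n2)n2nc(SCc3ccc(Br)cc3)nc2n1`, gives 4920 nM
- compound 3, `Cc1cc(Nc2cc(-c3ccc(F)cc3)[nH]n2)n2nc(SCc3ccc(Br)cc3)nc2n1`, gives 6210 nM

Compound 1 holds the lowest number of the three in this assay, yet the others sit close: compound 2 is the nearest and compound 3 the furthest, both within the scatter, so the three cannot be told apart with confidence. Within the data shown here, the only one-point step among them, a 1.3-fold higher number from compound 2 to compound 3 (0.10 log units; within the scatter), is likewise within the scatter.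

Compound 4, `CCCSc1nc2nc(C)cc(Nc3cc(-c4ccccc4)[nH]n3)n2n1`, has not been measured. It differs from compound 1 by ethyl in place of 1-benzothiophen-3-yl on a saturated chain carbon bound to a sulfur. The change at the sulfur-bound chain removes two fused aromatic rings and leaves a short alkyl chain, a far larger alteration than the halogen swap between compound 2 and compound 3, which concerns a different part of the molecule and so offers no guide to its size. Among the measured compounds shown here, with no measured step bearing on this change, the expectation rests on the change itself: the loss of a sizeable aromatic group is expected to weaken inhibition, giving a step of a 2.7-fold higher number from compound 1 to compound 4 (0.43 log units; beyond the scatter) beyond the scatter. Compound 4 is therefore estimated at 12000 nM in this assay, within a range of 3500 nM to 40000 nM.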

Compound 4, half-maximal inhibitory concentration: > 50000 nM
Compound 4: a limit, no number; the forecaster's own chance of this, stated with the estimate: 20%; middle value at least 4.1-fold (0.61 log units) from the limit.
By their numbers in this assay, from the lowest: compounds 1, 2 and 3 (each within the scatter of the next). At a limit, above all of these: compound 4.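

Among these compounds, at the sulfur-bound chain, putting ethyl in place of 1-benzothiophen-3-yl gives an at least 11-fold higher number from compound 1 to compound 4 (1.05 log units; beyond the scatter) and is the first single change here to reach beyond the scatter. Among the compounds shown here, the earlier compounds could not show this, as their only step, a 1.3-fold higher number from compound 2 to compound 3 (0.10 log units; within the scatter), lies elsewhere in the molecule and stays within the scatter. Compound 4 stands at a limit of the assay and not at a number: the limit of > 50000 nM in this assay, at which 1 of the 4 values shown sits.

The compounds shown do not separate the loss of the two fused aromatic rings from the shortening of the group on the sulfur: a benzyl group or a longer chain such as hexyl, placed there on the core of compound 1, would fall in that gap. What lies behind the size of this step also remains open.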